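Closing the Amine of Compound 3 into a Pyrrolidine Ring

The compounds below may be only part of what the source reports. "The series", "measured", "known", "first", "only" and "open" are said of these compounds alone.

Compound 1, `CC(CNCC1CC1)Oc1cccc2ccc(N)nc12`: 460 nM in a functional assay on IMR-32 cells with melanin-concentrating hormone receptor 1 (Homo sapiens) as the target, read by fluorescence; a lower number here means a stronger inhibitor, a higher number a weaker inhibitor
Compound 2, `CC(CNCC1CCCC1)Oc1cccc2ccc(N)nc12`: 100 nM in this assay
Compound 3, `CC(CNC1CCCC1)Oc1cccc2ccc(N)nc12`: 30 nM in this assay

Among these three, compound 3 has the lowest number in this assay, and both of its steps from the other two lie beyond the scatter: a 15-fold lower number from compound 1 to compound 3 (1.19 log units; beyond the scatter) and a 3.3-fold lower number from compound 2 to compound 3 (0.52 log units; beyond the scatter). The smaller change in ring size, a 4.6-fold lower number from compound 1 to compound 2 (0.66 log units; beyond the scatter), helped less than removing the methylene that separates the ring from the amine nitrogen.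

Compound 4, `CC(CN1CCCC1)Oc1cccc2ccc(N)nc12`, is not yet measured. It differs from compound 3 in one place: pyrrolidin-1-yl in place of cyclopentylamino on a saturated chain carbon, two bonds along the chain from an oxygen on an aromatic ring. The nitrogen thus becomes part of the ring and loses its hydrogen-bond donor. Among the measured compounds shown here, none of the measured steps makes this kind of change; they only vary ring size and the spacing between ring and nitrogen. The closest hint is that trimming one atom from the chain around this nitrogen has so far lowered the number, as in a 3.3-fold lower number from compound 2 to compound 3 (0.52 log units; beyond the scatter), but the donor was kept in every measured compound. A small loss is therefore expected rather than a gain. Compound 4 is estimated at 90 nM, within 25 nM to 350 nM, an expected step of a 3.0-fold higher number from compound 3 to compound 4 (0.48 log units; beyond the scatter).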

Compound 4, half-maximal inhibitory concentration: 360 nM
Beside the measured number, compound 4's estimate is 4.0-fold (0.60 log units) below it; measured number above the stated range.
By their numbers in this assay, from the lowest: compound 3; then compound 2; then compounds 4 and 1 (each within the scatter of the next).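

Swapping cyclopentylamino for pyrrolidin-1-yl at this position is no minor edit, even though the nitrogen stays and the ring stays five-membered: in this assay it gives a 12-fold higher number from compound 3 to compound 4 (1.08 log units; beyond the scatter), a large step. The group with no hydrogen-bond donor also compares poorly with the (cyclopentylmethyl)amino group, at a 3.6-fold higher number from compound 2 to compound 4 (0.56 log units; beyond the scatter), while it cannot be told apart from the (cyclopropylmethyl)amino group, at a 1.3-fold lower number from compound 1 to compound 4 (0.11 log units; within the scatter), so the advantage of compound 2 and compound 3 over compound 1 does not carry over to the pyrrolidin-1-yl group. Nothing measured beyond these numbers speaks to what lies behind the drop.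

Compound 4 loses the amine hydrogen, places the nitrogen inside the ring and carries one heavy atom fewer, all in a single step, so the compounds shown cannot say which of these matters. A cyclopentyl(methyl)amino group or a piperidin-1-yl ring at the same place would help pull these apart, and the compounds shown say nothing about either.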